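A few compounds are considered here, and "the series" means these few. Any claim that something is new, unique, unknown or untested is made for them only; others in the source may bear on it.

The account follows compound 1, `CC1CCN(C2CCN(S(=O)(=O)c3cn(C)cn3)CC2)CC1`, which in an ADME assay on HCT-116 cells (Homo sapiens) for cytotoxicity, read by CellTiter-Glo, with a stated time of 72 h (on this read-out higher numbers stand for weaker inhibition and lower numbers for stronger inhibition), gives only a limit of the assay, > 10000 nM. Compound 2, `COc1ccc(-c2cccc(S(=O)(=O)N3CCC(N4CCC(C)CC4)CC3)c2)cc1`, likewise reaches only a limit in this assay, > 5000 nM. Compound 3, `Cc1cc(C)c(S(=O)(=O)N2CCC(c3ccccc3)CC2)c(C)c1`, gives only a limit in this assay as well, > 5000 nM. No measured pair differing in a single place is available, so compound 1 stands only at a limit, as do the other two compounds shown. Compound 4, `CC1CCN(C2CCN(S(=O)(=O)c3cncc(Br)c3)CC2)CC1`, differs from compound 1 by 5-bromopyridin-3-yl in place of 1-methyl-1H-imidazol-4-yl on a sulfonyl sulfur. Since every value shown is a limit, no step beyond the scatter is expected; the step from compound 1 to compound 4 is expected to be a step that the limit leaves unreadable from compound 1 to compound 4. Compound 4 is therefore estimated at 15000 nM in this assay, within a range of 5000 nM to 50000 nM.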

Compound 4, half-maximal inhibitory concentration: > 10000 nM
Compound 4: no number, only a limit (the forecaster's own chance of this, stated with the estimate: 80%); the middle value is on the limit's open side.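

In this assay, for the compounds shown here, compound 1 and compound 4 each give only a limit, and no step between them can be read. The compounds shown leave open whether any group on the sulfonyl sulfur would give a number in this assay rather than a limit.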